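Substituent pattern on the styryl arm: expected step to compound 4

The source may report more compounds than this note shows. Statements on the series, on what has been measured and on what is new or still open speak of the compounds shown alone.

In a functional assay on ACHN cells (Homo sapiens) (on this read-out lower numbers stand for stronger inhibition of growth and higher numbers for weaker inhibition of growth), compound 1 (`O=S(=O)(/C=C/c1ccc(Cl)c(Cl)c1)Cc1ccc(Nc2ncnc3ccccc23)cc1`) gives 28000 nM as the higher of the two actual numbers here, with compound 3 (`O=S(=O)(/C=C/c1ccc(Cl)cc1Cl)Cc1ccc(Nc2ncnc3ccccc23)cc1`) at 100 nM for comparison. Compound 2 (`CC(C)(C)c1cc(/C=C/S(=O)(=O)Cc2ccc(Nc3ncnc4ccccc34)cc2)cc(C(C)(C)C)c1O`) returns > 100000 nM as a limit, not a number.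

Compound 4 (`O=S(=O)(/C=C/c1ccc(C(F)(F)F)cc1F)Cc1ccc(Nc2ncnc3ccccc23)cc1`) carries this change: 2-fluoro-4-(trifluoromethyl)phenyl in place of 3,4-dichlorophenyl on a double-bonded chain carbon bound to a double-bonded chain carbon. Among the measured compounds shown here, one measured step bears on it, a large one: a 280-fold lower number from compound 1 to compound 3 (2.45 log units; beyond the scatter) for 2,4-dichlorophenyl in place of 3,4-dichlorophenyl. The entering 2-fluoro-4-(trifluoromethyl)phenyl reads closer to the group of compound 3 (100 nM) but is not the same group, so a smaller move in that direction is expected (a 56-fold lower number from compound 1 to compound 4 (1.75 log units; beyond the scatter)). Compound 4 is estimated at 500 nM in this assay, with an expected range of 60 nM to 6000 nM.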

Compound 4, concentration for 50% growth inhibition: 100000 nM
The estimate for compound 4 lay 200-fold (2.30 log units) below the measured number; the whole stated range lies below it.
By their numbers in this assay, from the lowest: compound 3; then compound 1; then compound 4.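

In this assay, the aryl group on a double-bonded chain carbon tolerates little change: 2-fluoro-4-(trifluoromethyl)phenyl gives a 1000-fold higher number from compound 3 to compound 4 (3.00 log units; beyond the scatter), and also a 3.6-fold higher number from compound 1 to compound 4 (0.55 log units; beyond the scatter). The low number of compound 3 therefore stays with 2,4-dichlorophenyl and does not carry over to this other doubly substituted group. Compound 2 gives only a limit, not a number, and the number for compound 4 reaches that edge of the range: the limit of > 100000 nM in this assay, at which 1 of the 4 values shown sits.

The compounds shown leave open which of the two replacements in the ring accounts for the loss. 4-chloro-2-fluorophenyl and 2-chloro-4-(trifluoromethyl)phenyl would separate them.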